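The compounds below may be only part of what the source reports. "The series", "measured", "known", "first", "only" and "open" are said of these compounds alone.

Measured compounds in an assay on HEK293 cells for agonist activity at transient receptor potential cation channel subfamily M member 8 (Homo sapiens), read by fluorescence and calcium flux, with a stated time of 15 min; a higher number here means that more compound is needed for the effect, a lower number that less compound is needed:
compound 1 `CCN(Cc1cccs1)C(=O)COc1ccc(C(C)C)cc1` gives 397 nM
compound 2 `CCN(Cc1ccco1)C(=O)COc1ccc(C)cc1` gives 489 nM
compound 3 `Cc1ccc(OCC(=O)N(Cc2cccs2)CC(C)C)cc1` gives 900 nM

Compound 3 has the highest of the three numbers. Its value sits within the scatter of that of compound 2, so the two cannot be told apart, whereas the gap to compound 1 lies beyond the scatter, and compound 3 therefore needs more compound than compound 1 for the same effect. The step to compound 4 `C=CCN(Cc1cccs1)C(=O)COc1ccc(C)cc1` alters the group on a saturated chain carbon bound to an amide-type nitrogen: vinyl in place of isopropyl on a saturated chain carbon bound to an amide-type nitrogen. For the measured compounds named here, no measured pair shows this change, so the expectation rests on the spread of the three values in this assay, and the step from compound 3 to compound 4 is expected to be a 1.6-fold lower number from compound 3 to compound 4 (0.21 log units; within the scatter), a modest move toward a lower number that may not exceed the scatter. Compound 4 is therefore estimated at 550 nM, with a range from 250 nM to 1200 nM.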

Compound 4, half-maximal effective concentration: 20 nM
For compound 4 the middle estimate is 28-fold (1.44 log units) above the measured one, outside the stated range (below it).
By their numbers in this assay, from the lowest: compound 4; then compounds 1, 2 and 3 (each within the scatter of the next, the first and the last beyond it).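

In this assay, this position proves highly sensitive: vinyl in place of isopropyl on a saturated chain carbon bound to an amide-type nitrogen gives a 45-fold lower number from compound 3 to compound 4 (1.65 log units; beyond the scatter), a large step for a change that otherwise leaves the rest of the structure intact. For the compounds shown here, it is also the first pair here that differs in this one place. Nothing available accounts for the size of this step. 

As far as these compounds go, whether a propyl chain, a propargyl group or a cyclopropylmethyl group in place of the allyl would behave like compound 4 remains open. So does whether the same change would hold on the core of compound 1 or compound 2.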